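The source may report more compounds than this note shows. Statements on the series, on what has been measured and on what is new or still open speak of the compounds shown alone.

Two chalcones share a core and a single point of difference on the aryl ketone half. Compound 1, `COc1cc(C(=O)/C=C/c2cn(C)c3ccccc23)cc(N)c1OC`, carries an amine, and in a functional assay on HCT-8 cells (Homo sapiens) for antiproliferative activity, read by MTT assay, with a stated time of 48 h (a higher number here means a weaker inhibitor, a lower number a stronger inhibitor), compound 1 gives 605 nM. Compound 2, `COc1ccc2c(/C=C/C(=O)c3cc(OC)c(OC)c([N+](=O)[O-])c3)cn(C)c2c1`, carries a nitro group together with a methoxy on the fused ring system, and in this assay compound 2 gives 753 nM. On these two numbers compound 2 stands highest, and its nearest neighbour is compound 1, whose number lies within the usual scatter of it.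

The step to compound 3, `COc1cc(C(=O)/C=C/c2cn(C)c3ccccc23)cc([N+](=O)[O-])c1OC`, keeps the nitro group and changes only the fused ring system: hydrogen in place of methoxy on an aromatic carbon. For the measured compounds named here, no pair of measured compounds shows the effect of this change on its own, so the expectation rests on compound 2 alone and on the two numbers at hand. A step from compound 2 to compound 3 of a 1.1-fold higher number from compound 2 to compound 3 (0.03 log units; within the scatter) is expected, that is nothing beyond the scatter in either direction. Compound 3 is therefore estimated at 800 nM, with a range from 350 nM to 1800 nM.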

Compound 3, half-maximal inhibitory concentration: 1660 nM
Beside the measured number, compound 3's estimate is 2.1-fold (0.32 log units) below it; low and high end bracket the measured number.
By their numbers in this assay, from the lowest: compounds 1 and 2 (each within the scatter of the next); then compound 3.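

In this assay, hydrogen in place of methoxy on an aromatic carbon, with the nitro group kept, gives a 2.2-fold higher number from compound 2 to compound 3 (0.34 log units; beyond the scatter) and so shows that this position registers the change, which compounds 1 and 2 could not show, as they differ in more than one place. For the compounds shown here, with that carbon bearing hydrogen, nitro in place of amino gives a 2.7-fold higher number from compound 1 to compound 3 (0.44 log units; beyond the scatter) as the first reading of this exchange on its own, and both steps are modest. Nothing available accounts for either step. From the compounds shown here alone, it remains open whether the methoxy step carries over when an amino group stands in place of nitro. Also open, going by these compounds, is how an ethoxy group or a fluorine on that aromatic carbon, or an acetamide in place of nitro, would compare.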